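From ethyl to isopropyl: the step to compound 4

The source may hold more compounds than are shown below. What is called first, only, known or untested is meant among the compounds shown, and "the series" means these compounds.

Compound 1 `O=C(CSc1nc(Cc2c(F)cccc2F)cc(=O)[nH]1)c1ccccc1` gives > 67000 nM as a limit
Compound 2 `CC(C)c1c(Cc2c(Cl)cccc2Cl)nc(SCC(=O)c2ccccc2)[nH]c1=O` gives > 56000 nM as a limit
Compound 3 `CCc1c(Cc2c(F)cccc2F)nc(SCC(=O)c2ccccc2)[nH]c1=O` gives 56000 nM as a number

For the measured compounds named here, in an ADME assay on MT4 cells (Homo sapiens) for cytotoxicity, read by MTT assay (on this read-out higher numbers stand for lower toxicity in this test and lower numbers for higher toxicity in this test), compound 3 gives 56000 nM as the only actual number of the three. Compound 1 and compound 2 stand at limits. Compound 4 `CC(C)c1c(Cc2c(F)cccc2F)nc(SCC(=O)c2ccccc2)[nH]c1=O` arises from compound 3 by a single change methyl in place of hydrogen on a saturated chain carbon bound to an aromatic carbon and a saturated chain carbon which puts methyl in place of hydrogen on a saturated chain carbon bound to an aromatic carbon and a saturated chain carbon, so that ethyl becomes isopropyl. Going by the values given here, the only measured step that bears on this is an at least 1.1-fold lower number from compound 1 to compound 3 (0.07 log units; that floor lies within the scatter) and it adds a larger group at another place. Compound 2 also carries isopropyl but offers only a limit. Nothing here therefore points to a real shift in either direction. The estimated step is a 1.1-fold higher number from compound 3 to compound 4 (0.03 log units; within the scatter) and no change beyond the scatter is expected. For compound 4 the expected value is 60000 nM with an estimated range from 30000 nM to 120000 nM in this assay, and a limit rather than a number may well be reported.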

Compound 4, half-maximal cytotoxic concentration: > 60000 nM
Compound 4: no number, only a limit (the forecaster's own chance of this, stated with the estimate: 45%); the middle value lies on the limit itself.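

In this assay compound 4 carries a limit and not a number, and methyl in place of hydrogen on a saturated chain carbon bound to an aromatic carbon, which turns ethyl into isopropyl, gives an at least 1.0-fold higher number from compound 3 to compound 4 (0.02 log units; that floor lies within the scatter). This step can be read only as a floor because the value of compound 4 is a limit: the limit of > 60000 nM in this assay, at which 1 of the 4 values shown sits. The steps to compound 4 from compound 1 and from compound 2 cannot be read, as each joins two limits.

The compounds shown leave open where the actual value of compound 4 lies, and so whether isopropyl and ethyl differ at all in this test. They also leave open how a longer chain such as butyl, or a cyclopropyl group, would read at this place in this assay.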